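A Carboxy-Terminated Carbonate Tail Checked for Cell Tolerance

The source may hold more compounds than are shown below. What is called first, only, known or untested is meant among the compounds shown, and "the series" means these compounds.

Compound 1, `Cc1cn(C2CC(N=[N+]=[N-])C(COC(=O)OCCCCO)O2)c(=O)[nH]c1=O`, was examined in a functional assay on MT4 cells (Homo sapiens) for cytotoxicity; a higher number here means that more compound is tolerated, a lower number that less compound is tolerated. Compound 1 gives > 50000 nM, which is a limit of the assay and not a number. Compound 2, `Cc1cn(C2CC(N=[N+]=[N-])C(COC(=O)NCCCN)O2)c(=O)[nH]c1=O`, carries (3-aminopropyl)amino in place of 4-hydroxybutoxy on a carbonyl carbon. In this assay compound 2 gives > 50000 nM, again a limit. Compound 3, `Cc1cn(C2CC(N=[N+]=[N-])C(COC(=O)OCCCN)O2)c(=O)[nH]c1=O`, carries amino in place of hydroxymethyl on a saturated chain carbon, three bonds along the chain from an oxygen next to a carbonyl group. In this assay compound 3 gives > 50000 nM, also a limit. Accordingly the three steps are a step that the two limits leave unreadable from compound 1 to compound 2, a step that the two limits leave unreadable from compound 1 to compound 3 and a step that the two limits leave unreadable from compound 2 to compound 3, because of the limit of > 50000 nM in this assay, at which 3 of the 3 values shown sit.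

Compound 4, `Cc1cn(C2CC(N=[N+]=[N-])C(COC(=O)OCCCC(=O)O)O2)c(=O)[nH]c1=O`, differs from compound 1 by carboxy in place of hydroxymethyl on a saturated chain carbon, three bonds along the chain from an oxygen next to a carbonyl group. Going by the values given here, the only step at the same place on the chain, a step that the two limits leave unreadable from compound 1 to compound 3, gives no readable size, so none of the measured steps sets a direction for this assay. Compound 4 is therefore expected to give 100000 nM, within 30000 nM to 400000 nM, most probably again reported only as a limit. The expected step is a step that the limit leaves unreadable from compound 1 to compound 4.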

Compound 4, half-maximal cytotoxic concentration: > 50000 nM
Compound 4 gave a limit, no number; the forecaster's own chance of this, stated with the estimate: 85%; the middle value is on the limit's open side.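

Compound 4 adds no readable step against compound 1, compound 2 or compound 3, because all four values stop at the same point in this assay: the limit of > 50000 nM in this assay, at which 4 of the 4 values shown sit.

The compounds shown leave open how much of each compound is actually tolerated, and whether these changes in the chain alter that amount at all.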